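This account rests on a few compounds, and the source may have more. Where it says the series, first, only, none or still open, it means among the compounds named here.

Compound 1: `CCOc1ccc(NC(=O)Nc2cccc(CNc3nccnc3Cl)c2)cc1` — 7240 nM
Compound 2: `CN(C)c1ccc(NC(=O)Nc2cccc(CNc3nccnc3Cl)c2)cc1` — 11500 nM

Among the measured compounds shown here, in a functional assay on MGC-803 cells (Homo sapiens) for antiproliferative activity, read by MTT assay, with a stated time of 48 h (on this read-out lower numbers stand for stronger inhibition and higher numbers for weaker inhibition), compound 2 stands at the highest of the two numbers, the only measured step being a 1.6-fold higher number from compound 1 to compound 2 (0.20 log units; within the scatter). Compound 3, `O=C(Nc1cccc(CNc2nccnc2Cl)c1)NC1CCCC1`, differs from compound 2 by cyclopentyl in place of 4-(dimethylamino)phenyl on an amide-type nitrogen. For the measured compounds named here, the only measured step, swapping one aromatic substituent for another, stayed within the scatter and does not touch a ring-for-ring exchange, so no direction beyond the scatter is expected here. Compound 3 is therefore estimated at 10000 nM, with a range of 3000 nM to 33000 nM, meaning an expected step of a 1.2-fold lower number from compound 2 to compound 3 (0.06 log units; within the scatter).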

Compound 3, half-maximal inhibitory concentration: 23400 nM
The estimate for compound 3 lay 2.3-fold (0.37 log units) below the measured number; the measured number falls inside the stated range.
By their numbers in this assay, from the lowest: compounds 1 and 2 (each within the scatter of the next); then compound 3.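

At the amide-type nitrogen, the exchange of an aryl group for cyclopentyl moved the number beyond the scatter in this assay, which the earlier change on the aromatic carbon had not done. The steps are a 2.0-fold higher number from compound 2 to compound 3 (0.31 log units; beyond the scatter) and a 3.2-fold higher number from compound 1 to compound 3 (0.51 log units; beyond the scatter), both modest and both towards weaker inhibition. Nothing available explains this shift. It remains open whether the loss follows the aromatic ring itself or the particular cyclopentyl group, since an unsubstituted phenyl, a cyclohexyl or a longer alkyl chain at this nitrogen is not among the compounds shown.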